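Flipping Two Double Bonds in a Cytotoxicity Test

The compounds below may be only part of what the source reports. "The series", "measured", "known", "first", "only" and "open" are said of these compounds alone.

Compound 1 `CCCCCCCC/C=C\c1c(C)cc(C)nc1CCCOC` has "not determined" (no result reported) as its entry in an ADME assay on NIH3T3 cells (Mus musculus) for cytotoxicity, read by neutral red uptake, with a stated time of 48 h (on this read-out higher numbers stand for lower toxicity in this test and lower numbers for higher toxicity in this test), and so adds no number to the comparison. Among the compounds with values here, compound 2 `CCCCCCCC/C=C\c1c(C)c(/C=C/CCCCCCCC)c(C)[n+]2c1CCC2` gives 3.2 uM and compound 3 `CCCCCCCC/C=C\c1c(C)cc(C)[n+]2c1CCC2` gives 1.9 uM in this assay and these are the only two numbers available. Within the data shown here, compound 2 therefore stands within the scatter of its sole neighbour, and the two cannot be ranked.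

Against compound 2 the unmeasured compound 4 `CCCCCCCC/C=C\c1c(C)c(/C=C/CCCCCCCC)c2[n+](c1C)CCC2` differs in this way: the two compounds have the same atoms and bonds and differ only in configuration as drawn: 2 of 2 stereo elements differ; a double bond is drawn E in compound 2 and Z in compound 4; a double bond is drawn Z in compound 2 and E in compound 4 and that is the whole structural change.

Among the measured compounds shown here, the one measured step is a 1.7-fold lower number from compound 2 to compound 3 (0.23 log units; within the scatter) and in it a hydrogen atom takes the place of an entire chain on an aromatic carbon. Even so large an edit leaves the two numbers within the scatter of each other. For the measured compounds named here, that step bears on the question only indirectly, since no measured pair tests double-bond configuration alone. A step beyond the scatter is therefore not expected, and the estimated size is a 1.1-fold lower number from compound 2 to compound 4 (0.03 log units; within the scatter) in this assay with neither direction favoured by the data. For compound 4 the expected value is 3 uM with an estimated range from 1.3 uM to 7 uM as the likely span of a measurement.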

Compound 4, half-maximal toxic concentration: 3.7 uM
Compound 4: the middle estimate sits 1.2-fold (0.09 log units) below what was measured; measured number inside the range.
By their numbers in this assay, from the lowest: compounds 3, 2 and 4 (each within the scatter of the next).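

In this assay the pair gives a 1.2-fold higher number from compound 2 to compound 4 (0.06 log units; within the scatter), so the two compounds cannot be told apart, and reversing the drawn configuration of both double bonds at once leaves no readable mark on this cytotoxicity read-out. The earlier measured step removed an entire chain, which left open what the geometry of the double bonds contributes, whereas this pair isolates that one feature, and the comparison rests on a single point: the fact that compounds 2 and 4 differ only in the configuration as drawn. For these two compounds, then, this test gives no reason to treat the two double-bond arrangements as different, although that finding covers only the paired change and only this one cell test.

The compounds shown leave open what each double bond does on its own, given that both change together here, and whether compound 3, with its single chain, would behave the same way if its one double bond were reversed. They also leave open whether a chain ending in a carboxylic acid or an amine, in place of the plain carbon chains, would move the number beyond the scatter.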